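A few compounds are considered here, and "the series" means these few. Any claim that something is new, unique, unknown or untested is made for them only; others in the source may bear on it.

Working notes on the series. Among the measured compounds shown here, in a functional assay on SK-BR-3 cells (Homo sapiens) for antiproliferative activity, read by MTT assay, with a stated time of 48 h (on this read-out lower numbers stand for stronger inhibition and higher numbers for weaker inhibition), compound 2 `COc1ccc(C(=O)Nc2ccc(N(C)S(C)(=O)=O)c(OCc3cc(C(F)(F)F)ccc3C)c2)cc1` gives 2030 nM, the lower of the two numbers measured; compound 1 `CCCCCCOc1cc(NC(=O)c2ccc3ccccc3c2)ccc1N(C)S(C)(=O)=O` gives 64300 nM in this assay, and the two differ at more than one place, so no single-point step is available. Compound 3 `Cc1ccc(C(F)(F)F)cc1COc1cc(NC(=O)c2ccc3ccccc3c2)ccc1N(C)S(C)(=O)=O` carries the change naphthalen-2-yl in place of 4-methoxyphenyl on a carbonyl carbon relative to compound 2. Compound 1, which carries the same naphthalene amide, gave the weaker value, but its other difference leaves the contribution of the amide change undetermined. For compound 3 a step of a 1.7-fold higher number from compound 2 to compound 3 (0.24 log units; within the scatter) toward a slightly higher number is expected, not clearly beyond the scatter. Compound 3 is estimated at 3500 nM, range 900 nM to 14000 nM.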

Compound 3, half-maximal inhibitory concentration: 18400 nM
Beside the measured number, compound 3's estimate is 5.3-fold (0.72 log units) below it; measured number outside the range, above it.
By their numbers in this assay, from the lowest: compound 2; then compound 3; then compound 1.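

Naphthalen-2-yl in place of 4-methoxyphenyl on a carbonyl carbon gives a 9.1-fold higher number from compound 2 to compound 3 (0.96 log units; beyond the scatter) in this assay, so this single change weakens inhibition with the 2-methyl-5-(trifluoromethyl)phenyl group kept in place. With the naphthalen-2-yl amide held constant, 2-methyl-5-(trifluoromethyl)phenyl in place of pentyl on a saturated chain carbon bound to an oxygen on an aromatic ring gives a 3.5-fold lower number from compound 1 to compound 3 (0.54 log units; beyond the scatter) in this assay, so the amide change does not account for all of the weak value of compound 1.

Going by these compounds, it remains open whether an amine or a carboxylic acid in place of the methoxy group would keep the value of compound 2. On these data alone, it also remains open whether 4-methoxyphenyl would give a similar step on the chain of compound 1. No measurement here gives a cause for either step.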